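Swapping the aryl sulfonamide for an aniline on the pyrazole

The compounds below may be only part of what the source reports. "The series", "measured", "known", "first", "only" and "open" are said of these compounds alone.

Compound 1 `CN1CCN(CCNCc2cn(-c3ccc(F)cc3F)nc2-c2ccc(S(=O)(=O)N(C)C)cc2)CC1`: > 20000 nM
Compound 2 `Cc1ccccc1-c1nn(-c2ccc(F)cc2F)cc1CNCCCN1CCN(C)CC1`: > 20000 nM

In an ADME assay on Huh-7 cells (Homo sapiens) for cytotoxicity (on this read-out lower numbers stand for higher toxicity in this test and higher numbers for lower toxicity in this test), compound 1 gives > 20000 nM, which is a limit of the assay rather than a number. In this assay compound 2 gives > 20000 nM, likewise a limit. Among the measured compounds shown here, both values rest on (the limit of > 20000 nM in this assay, at which 2 of the 2 values shown sit), so compound 1 stands at the limit together with the only other compound, and no step between measured compounds is available.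

Compound 3 `CN1CCN(CCNCc2cn(-c3ccc(F)cc3F)nc2-c2cccc(N(C)C)c2)CC1` carries 3-(dimethylamino)phenyl in place of 4-(dimethylsulfamoyl)phenyl on an aromatic carbon. For the measured compounds named here, no measured step speaks to this change, and the two measured compounds differ from each other in more than one place. Given that compound 1 shows > 20000 nM, the step that the limit leaves unreadable from compound 1 to compound 3 is expected to be none beyond the scatter, with the limit itself the most probable outcome. Compound 3 is therefore estimated at 25000 nM in this assay, in the range 10000 nM to 60000 nM.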

Compound 3, half-maximal cytotoxic concentration: > 20000 nM
Compound 3 gave a limit, no number; the forecaster's own chance of this, stated with the estimate: 80%; the middle value lies beyond the limit too.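

Among the compounds shown here, no step from compound 1 to compound 3 can be read in this assay as both compounds give only a limit, and all the values shown stand at that same limit: the limit of > 20000 nM in this assay, at which 3 of the 3 values shown sit. From the compounds shown here alone, what stays open is whether 3-(dimethylamino)phenyl in place of 4-(dimethylsulfamoyl)phenyl changes cytotoxicity at all.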